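Dropping One Ring Methyl from a Selenium Ether Amine

A few compounds are considered here, and "the series" means these few. Any claim that something is new, unique, unknown or untested is made for them only; others in the source may bear on it.

Three compounds have so far been examined in an assay on isolated protein for inhibition of Amine oxidase [flavin-containing] B (Homo sapiens), read by fluorescence and spectrophotometry; a lower number here means a stronger inhibitor, a higher number a weaker inhibitor. Compound 1, `CC(N)CSc1ccccc1Br`, gives 64800 nM. Compound 3, `CC(N)C[Se]c1ccc(N(C)C)cc1`, gives 21300 nM. Compound 2, `Cc1cccc(C)c1[Se]CC(C)N`, gives 2790 nM, the lowest of the three numbers; its distances to compound 3 and to compound 1 both lie beyond the usual scatter, so compound 2 stands as the strongest inhibitor of the set in this assay.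

Compound 4, `Cc1ccccc1[Se]CC(C)N`, has not yet been measured. It differs from compound 2 in a single place: hydrogen in place of methyl on an aromatic carbon. One of the two ring methyls is gone; everything else is kept.

Among the measured compounds shown here, no pair of measured compounds isolates this kind of change, so nothing in the data directly shows what the loss of one ring methyl does in this assay. The change is small, a single heavy atom. The expectation is a modest weakening, or no shift beyond the scatter. For compound 4 the expected step is a 1.6-fold higher number from compound 2 to compound 4 (0.21 log units; within the scatter). Compound 4 is therefore estimated to give 4500 nM, with a range from 1500 nM to 15000 nM.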

Compound 4, half-maximal inhibitory concentration: 16700 nM
Beside the measured number, compound 4's estimate is 3.7-fold (0.57 log units) below it; measured number above the stated range.
By their numbers in this assay, from the lowest: compound 2; then compounds 4 and 3 (each within the scatter of the next); then compound 1.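

In this assay, replacing methyl with hydrogen on this aromatic carbon, ortho to a group of 5 heavy atoms and meta to a methyl group, gives a 6.0-fold higher number from compound 2 to compound 4 (0.78 log units; beyond the scatter) and so weakens inhibition. Among the compounds shown here, this is the first pair in the set to differ in only one place, and it shows that this methyl has a measurable bearing on the inhibition of the enzyme: the change removes just 1 heavy atom, with no hydrogen-bond donor, hydrogen-bond acceptor or net charge involved, yet the step lies beyond the scatter. Nothing measured here explains why this methyl counts for so much.

The compounds shown leave open whether the gain depends on methyl itself or whether another group on this aromatic carbon, such as ethyl, chlorine or methoxy, would serve as well. They also leave open how much the methyl that remains in compound 4 contributes, since no compound shown has hydrogen in its place while keeping the rest of compound 4 unchanged.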